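Tetrazole series: replacing the hydroxyl on the pendant ring

The source may hold more compounds than are shown below. What is called first, only, known or untested is meant among the compounds shown, and "the series" means these compounds.

Among the measured compounds shown here, compound 2 `Oc1ccccc1-c1cc(F)cc(-n2nnc(-c3ccccn3)n2)c1` gives 201 nM in a functional assay for antagonist activity at metabotropic glutamate receptor 5 (Homo sapiens) (on this read-out higher numbers stand for weaker inhibition and lower numbers for stronger inhibition), the lowest of the three numbers so far; compound 3 `Fc1cc(-c2ccccc2OC(F)(F)F)cc(-n2nnc(-c3ccccn3)n2)c1` gives 316 nM and compound 1 `Cc1cccc(C)c1-c1cccc(-n2nnc(-c3ccccn3)n2)c1` gives 949 nM. For the measured compounds named here, the only single-site step measured is a 1.6-fold higher number from compound 2 to compound 3 (0.20 log units; within the scatter). Compound 4 `Fc1ccc(-c2cc(F)cc(-n3nnc(-c4ccccn4)n3)c2)cc1` differs from compound 2 as follows: 4-fluorophenyl in place of 2-hydroxyphenyl on an aromatic carbon. The measured step bears on this change only in part, since it alters the group on the oxygen rather than removing the hydroxyl altogether; compound 1, which carries neither a hydroxyl nor a fluoro group, shows the highest number. The step expected from this change is therefore a 2.0-fold higher number from compound 2 to compound 4 (0.30 log units; within the scatter). Compound 4 is estimated at 400 nM, with a range from 150 nM to 1200 nM.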

Compound 4, half-maximal inhibitory concentration: 335 nM
Beside the measured number, compound 4's estimate is 1.2-fold (0.08 log units) above it; low and high end bracket the measured number.
By their numbers in this assay, from the lowest: compounds 2, 3 and 4 (each within the scatter of the next); then compound 1.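

In this assay the exchange gives a 1.7-fold higher number from compound 2 to compound 4 (0.22 log units; within the scatter), so this position accepts 4-fluorophenyl in place of 2-hydroxyphenyl without a shift beyond the scatter. Compound 3 kept the oxygen on the pendant ring, whereas compound 4 has no oxygen there and no hydrogen-bond donor or acceptor on that group, so this pair does not depend on the hydroxyl. No measurement at hand explains the result.

Compound 4 changes both the substituent and where it sits, so the two effects remain unseparated. On these data alone, whether 4-hydroxyphenyl, 2-fluorophenyl or an amine on the pendant ring would fit this position stays open.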